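The compounds below may be only part of what the source reports. "The series", "measured", "known", "first", "only" and "open" are said of these compounds alone.

Measured in a physicochemical assay for lipophilicity, at pH 7.4; a lower number here means a more polar compound, a higher number a more lipophilic compound:
- Compound 1 `Cc1cc(C(=O)NCc2cccnc2)nn1Cc1cc(Cl)ccc1OCc1ccccc1`: > 3.7, a limit of the assay and not a number
- Compound 2 `Cc1cc(NC(=O)C2CCCC2)nn1Cc1cc(Cl)ccc1OCc1ccccc1`: 3.5

Within the data shown here, compound 2 gives 3.5, the only true number so far. Compound 3 `Cc1cc(NC(=O)CC2CCCCC2)nn1Cc1cc(Cl)ccc1OCc1ccccc1` differs from it in one group, with cyclohexylmethyl in place of cyclopentyl on a carbonyl carbon. Among the measured compounds shown here, the only measured step, a number at least 0.20 log units lower from compound 1 to compound 2 (that floor lies within the scatter), lies on an aromatic carbon, so it is just a loose guide here. Only carbon is counted in the swap, so a rise in this assay is expected, an estimated a number 0.50 log units higher from compound 2 to compound 3 (beyond the scatter). Compound 3 is estimated at 4, with a range of 3.6 to 4.5, and the result may prove to be only a limit.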

Compound 3, distribution coefficient: 3.2
Compound 3: the middle estimate sits 0.80 log units above what was measured; measured number outside the range, below it.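

Swapping cyclopentyl for cyclohexylmethyl on a carbonyl carbon adds carbon, yet this assay records a number 0.30 log units lower from compound 2 to compound 3 (within the scatter), so carbon count alone does not set the reading for this pair. Among these compounds, the wider swap on an aromatic carbon gives a number at least 0.50 log units lower from compound 1 to compound 3 (beyond the scatter) and is the only step here that clears the scatter. Compound 1 stands at a limit of the assay, not a number, so that step is only a floor: the limit of > 3.7 in this assay, at which 1 of the 3 values shown sits.

Still open, as far as these compounds go, is whether an amine on the ring, or a carboxylic acid at the end of a longer chain, would shift the reading at this position beyond the scatter.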